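A few compounds are considered here, and "the series" means these few. Any claim that something is new, unique, unknown or untested is made for them only; others in the source may bear on it.

Measured in a functional assay on HepG2 cells (Homo sapiens) for antiproliferative activity, read by CCK-8 assay, with a stated time of 72 h, tested at 2 uM; a lower number here means a weaker effect, a higher number a stronger effect of the compound at the concentration tested:

Compound 1 `Nc1ccccc1NC(=O)c1ccc(Cn2cnc3c(Nc4ccccc4)nc(Cl)nc32)cc1`: 49.6%
Compound 2 `CCCCn1cnc2c(Nc3ccccc3)nc(NCOCc3ccc(C(=O)Nc4ccccc4N)cc3)nc21`: 46.6%
Compound 3 `Nc1ccccc1NC(=O)c1ccc(Cn2cnc3c(Nc4cccc(Cl)c4)nc(Cl)nc32)cc1`: 29.9%

Compound 3 differs from compound 1 by one change, (chloro in place of hydrogen on an aromatic carbon), and in this assay that change made the step of a number 19.7 percentage points lower from compound 1 to compound 3 (beyond the scatter). Compound 1 and compound 2 lie within the scatter of each other, and how their two cores differ is not broken down here. Compound 4 `CCCCn1cnc2c(Nc3cccc(Cl)c3)nc(NCOCc3ccc(C(=O)Nc4ccccc4N)cc3)nc21` differs from compound 2 by chloro in place of hydrogen on an aromatic carbon, the same change on the same kind of place, so it occurs two times among the compounds shown. Among the measured compounds shown here, the step from compound 2 to compound 4 in this assay is expected to be a number 18.6 percentage points lower from compound 2 to compound 4 (beyond the scatter), a step of about the size seen before, an expectation that rests on the single step of a number 19.7 percentage points lower from compound 1 to compound 3 (beyond the scatter) alone. Compound 4 is therefore estimated at 28% in this assay, with a lower end of 15% and an upper end of 42%.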

Compound 4, a percentage reported as inhibition, at one concentration (the size of the read-out at that concentration, not a potency): 30.6%
Compound 4: the middle estimate sits 2.6 percentage points below what was measured, within the range that was stated.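

In this assay the change from phenyl to 3-chlorophenyl gave a number 16 percentage points lower from compound 2 to compound 4 (beyond the scatter) and so went the same way as on the core of compound 1. The size of the step carried over from one core to the other: the same change on two cores in this assay, a number 19.7 percentage points lower (beyond the scatter) from compound 1 to compound 3 and a number 16 percentage points lower (beyond the scatter) from compound 2 to compound 4, 3.7 percentage points apart, within the scatter of two such steps. This rests on two pairs only, so it shows that the change behaved alike on these two cores, but not that it would do so on any other core in the series, nor why it lowers the read-out.

The compounds shown leave open what other groups would do on that ring in place of chloro, such as fluoro, methoxy or an amine. They also leave open whether a longer chain in place of the butyl group of compound 4 would alter the step.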